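The source may report more compounds than this note shows. Statements on the series, on what has been measured and on what is new or still open speak of the compounds shown alone.

Working notes on the series.

Three compounds have been run in a functional assay on NCI-H322M cells (Homo sapiens) for cytotoxicity, read by sulforhodamine B assay, with a stated time of 48 h; a lower number here means a stronger inhibitor of growth, a higher number a weaker inhibitor of growth. Compound 1 `ClCc1ccccc1Cn1cnc2c(Cl)nc(Cl)nc21` gives 3270 nM. Compound 2 `ClCc1ccccc1Cn1cnc2c(Cl)ncnc21` gives 13800 nM. Compound 3 `ClCc1cccc(Cn2cnc3c(Cl)ncnc32)c1` gives 3460 nM. Compound 1 and compound 3 sit within the usual scatter of each other, so nothing is read from their order. Compound 2 and compound 3 share the same atoms joined differently; the difference between the two cores is not broken down here.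

For the measured compounds named here, the one counted step so far is chloro in place of hydrogen on an aromatic carbon, and it gave a 4.2-fold lower number from compound 2 to compound 1 (0.63 log units; beyond the scatter).

Compound 4 `ClCc1cccc(Cn2cnc3c(Cl)nc(Cl)nc32)c1` is not yet measured. It differs from compound 3 by chloro in place of hydrogen on an aromatic carbon, the same change, at a place described in the same words, as from compound 2 to compound 1. It occurs twice among these compounds, once measured. Going by the values given here, only that single pair supports the expectation, and compound 3 rests on a different core from compound 2, so the transfer is not certain.

On that basis the expected step is a 4.1-fold lower number from compound 3 to compound 4 (0.61 log units; beyond the scatter) in this assay, because compound 1 against compound 2 showed a 4.2-fold lower number from compound 2 to compound 1 (0.63 log units; beyond the scatter). The estimate for compound 4 in this assay is therefore 850 nM, with an expected span from 300 nM to 2600 nM. The estimate allows for the step on the new core being smaller than the one already seen.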

Compound 4, concentration for total growth inhibition: 5120 nM
For compound 4 the middle estimate is 6.0-fold (0.78 log units) below the measured one, and the stated range ends below it.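

In this assay, for the compounds shown here, chloro in place of hydrogen on the aromatic carbon between two ring nitrogen atoms gives a 1.5-fold higher number from compound 3 to compound 4 (0.17 log units; within the scatter), so on the core of compound 3 this change produces no step that can be told from the scatter. The step seen on the core of compound 1 therefore does not carry over to the core of compound 4, and the two results differ by more than repeat measurement would explain: the same change on two cores in this assay, a 4.2-fold lower number (0.63 log units; beyond the scatter) from compound 2 to compound 1 and a 1.5-fold higher number (0.17 log units; within the scatter) from compound 3 to compound 4, 6.2-fold (0.80 log units) apart, beyond the scatter of two such steps. This shows that, in these two pairs, the outcome of the change depends on the core, but it does not show why, and two pairs give no rule for any further core.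

On these data alone, it remains open whether this dependence on the core is particular to chloro or would also appear with an amine or a methoxy group on that same aromatic carbon, measured on both cores. The chloromethyl group is present in all four compounds, so the compounds shown also leave open whether the gap between the two steps would persist with a hydroxymethyl group in its place.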